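Aryl acid swap at the linker end of compound 3

A few compounds are considered here, and "the series" means these few. Any claim that something is new, unique, unknown or untested is made for them only; others in the source may bear on it.

Compound 3 `Cc1c(OCCCCOc2ccc(C(=O)O)cc2Cl)ccc(C(=O)CC2CCCC2)c1O` stands lowest of the three numbers obtained in an assay on HEK293 cells for positive allosteric modulation of metabotropic glutamate receptor 3 (Rattus norvegicus), read by thallium flux, with a stated time of 2.5 min; on this read-out higher numbers stand for larger maximal responses and lower numbers for smaller maximal responses: compound 3 gives 27.4%, compound 2 `COc1cc(C(=O)O)ccc1OCCCCOc1ccc(C(=O)CC(C)C)c(O)c1C` gives 73.9%, and compound 1 `COc1cc(C(=O)O)ccc1OCCCCOc1ccc(C(=O)CC(C)(C)C)c(O)c1C` gives 109%. Going by the values given here, the only single-point step measured is a number 35.1 percentage points lower from compound 1 to compound 2 (beyond the scatter), which alters the ketone side chain and not the aryl acid end, so it does not bear on the present change. Compound 4 `Cc1ccc(C(=O)O)cc1OCCCCOc1ccc(C(=O)CC2CCCC2)c(O)c1C` differs from compound 3 by 5-carboxy-2-methylphenyl in place of 4-carboxy-2-chlorophenyl on an oxygen on a saturated carbon. Among the compounds with values here, no measured step covers this change; the numbers of compounds 1 and 2 show only that other aryl acid patterns can sit higher. The step is therefore expected to be a number 14.6 percentage points higher from compound 3 to compound 4 (beyond the scatter), upward but uncertain. Compound 4 is estimated at 42%, within 15% to 75%.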

Compound 4, largest response reached (reported as percent of maximum), in percent of the reference or control that the assay uses: 26.9%
Compound 4: the middle estimate sits 15.1 percentage points above what was measured; the range from low to high includes it.
By their numbers in this assay, from the lowest: compounds 4 and 3 (each within the scatter of the next); then compound 2; then compound 1.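

Going by these compounds alone, the first reading on the aryl acid end is flat: 5-carboxy-2-methylphenyl in place of 4-carboxy-2-chlorophenyl on an oxygen on a saturated carbon gives a number 0.5 percentage points lower from compound 3 to compound 4 (within the scatter) in this assay. With this ketone side chain, the read-out does not separate the two aryl acid groups. Nothing available explains this result.

Open, on these data alone, is whether the swap reads the same with the ketone side chains of compound 1 and compound 2, and whether moving the carboxy group and exchanging chlorine for methyl would each matter alone. Also open, as far as these compounds go, is what a tetrazole in place of the carboxylic acid would do to the maximal response.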